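Heteroaryl replacements on the ring amine nitrogen

A few compounds are considered here, and "the series" means these few. Any claim that something is new, unique, unknown or untested is made for them only; others in the source may bear on it.

The series shares one core; compound 1 `O=C(CN1CCN(c2cccc(F)c2)CC1)Nc1nc2c(s1)CCCC2`, compound 2 `CC1CCc2sc(NC(=O)CN3CCN(c4ccc(F)cc4)CC3)nc2C1` and compound 3 `O=C(CN1CCN(c2ccc(F)cn2)CC1)Nc1nc2c(s1)CCCC2` differ in the group carried on the amine nitrogen in a ring and, for compound 2, in a methyl on the core. In an assay on isolated protein for inhibition of long-chain fatty acid transport protein 1 (Mus musculus), read by scintillation counting, with a stated time of 20 min (a higher number here means a weaker inhibitor, a lower number a stronger inhibitor), compound 1 gives only > 10000 nM, which is a limit of the assay and not a number. In this assay compound 2 gives 5100 nM. In this assay compound 3 gives 600 nM. Compound 1 sits at the limit of > 10000 nM in this assay, at which 1 of the 3 values shown sits. Going by the values given here, the one step with a single change runs an at least 16-fold lower number from compound 1 to compound 3 (1.22 log units; beyond the scatter). Compound 3 has the lowest of the two numbers shown; compound 2 stands higher by an amount beyond the scatter.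

Compound 4 `O=C(CN1CCN(c2nccs2)CC1)Nc1nc2c(s1)CCCC2` is not yet measured. It differs from compound 3 by 1,3-thiazol-2-yl in place of 5-fluoropyridin-2-yl on an amine nitrogen in a ring. Among the compounds with values here, the step from compound 1 to compound 3 is the only measured step at this place, and it exchanged one six-membered aromatic ring for another; no measured step exchanges a six-membered ring for a five-membered one here, so it gives only loose guidance. In this assay the number for compound 4 is expected to shift by a 1.7-fold higher number from compound 3 to compound 4 (0.22 log units; within the scatter), a step not beyond the scatter. The estimate for compound 4 in this assay is 1000 nM, with a range from 300 nM to 4000 nM.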

Compound 4, half-maximal inhibitory concentration: 7900 nM
Compound 4: middle estimate off by 7.9-fold (0.90 log units), on the low side, and the stated range ends below it.
By their numbers in this assay, from the lowest: compound 3; then compounds 2 and 4 (each within the scatter of the next). At a limit, above all of these: compound 1.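

In this assay, the group on the amine nitrogen in a ring is sensitive to more than the exchange of one six-membered aromatic ring for another: with 1,3-thiazol-2-yl in place of 5-fluoropyridin-2-yl, the step runs a 13-fold higher number from compound 3 to compound 4 (1.12 log units; beyond the scatter). A hetero atom in the aromatic ring at this place therefore does not by itself carry the low number, which among the compounds shown belongs to compound 3 at 600 nM. With 1,3-thiazol-2-yl in place of 3-fluorophenyl, the step runs an at least 1.2-fold lower number from compound 1 to compound 4 (0.10 log units; that floor lies within the scatter), and it shows no clear gain, because its starting point is a limit of the assay and not a number: the limit of > 10000 nM in this assay, at which 1 of the 4 values shown sits.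

The step to compound 4 changes ring size, the hetero atoms and the fluorine together, so the compounds shown do not tell which of these carries the loss. On these data alone, how a pyridin-2-yl without the fluorine, a pyrimidin-2-yl or a 1,3-thiazol-2-yl bearing a fluorine would read in this assay remains open, and these are the groups that would separate the three changes.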